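Permeability notes on a shared urea core: chloro for ethyl

A few compounds are considered here, and "the series" means these few. Any claim that something is new, unique, unknown or untested is made for them only; others in the source may bear on it.

Measured so far in an ADME assay for permeability, using PAMPA, at pH 7.4; on this read-out higher numbers stand for higher permeability and lower numbers for lower permeability:
compound 1, `CCc1ccc(NC(=O)Nc2cc(C)nc3ccccc23)cc1`: 535 10^-6 cm/s
compound 2, `COc1ccc(NC(=O)Nc2cc(C)nc3ccccc23)cc1OC`: 552 10^-6 cm/s
compound 3, `Cc1cc(NC(=O)Nc2ccccc2C(F)(F)F)c2ccccc2n1`: 945 10^-6 cm/s

Compound 1 carries the lower end of these three numbers, but compound 2 and compound 3 both sit within the usual scatter of it, so no order among the three can be read from this assay; the set is uniformly high. Within the data shown here, no pair of measured compounds differs in only one place, so no single-change step is available.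

Compound 4, `Cc1cc(NC(=O)Nc2ccc(Cl)cc2)c2ccccc2n1`, is compound 1 with chloro in place of ethyl on an aromatic carbon. On the numbers shown, a step of no size beyond the scatter is expected, and the step from compound 1 to compound 4 is estimated as a 1.1-fold higher number from compound 1 to compound 4 (0.05 log units; within the scatter). In this assay compound 4 is accordingly expected near 600 10^-6 cm/s, within 350 10^-6 cm/s to 1000 10^-6 cm/s.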

Compound 4, apparent permeability: 537 10^-6 cm/s
The estimate for compound 4 lay 1.1-fold (0.05 log units) above the measured number; the measured number falls inside the stated range.
By their numbers in this assay, from the lowest: compounds 1, 4, 2 and 3 (each within the scatter of the next).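

In this assay, among these compounds, chloro in place of ethyl on an aromatic carbon, para to a large group, gives a 1.0-fold higher number from compound 1 to compound 4 (0.00 log units; within the scatter) as the first single-change step in the set. Among the compounds shown here, at this position, the read-out therefore does not separate a chloro group from an ethyl group, which the earlier compounds, differing in more than one place, could not show. No measurement available here bears on why the two groups read alike.

Still open, going by these compounds, is whether an amine or a carboxylic acid at this position would give a step beyond the scatter. On these data alone, a longer chain in place of ethyl is equally open.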